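A Furan Ring in Place of the Fluorophenyl Group

The compounds below may be only part of what the source reports. "The series", "measured", "known", "first", "only" and "open" are said of these compounds alone.

Of the compounds shown here, three built on a shared core have been tested in a functional assay on CHO cells for agonist activity at Free fatty acid receptor 1 (Homo sapiens), read by calcium flux; a higher number here means that more compound is needed for the effect, a lower number that less compound is needed. Compound 1 `Cc1cccc(-c2cccc(NC(=O)c3nnc(CCC(=O)O)s3)c2)c1` gives 760 nM, compound 2 `O=C(O)CCc1nnc(C(=O)Nc2cccc(-c3cccc(Cl)c3)c2)s1` gives 1690 nM, and compound 3 `O=C(O)CCc1nnc(C(=O)Nc2cccc(-c3ccc(F)cc3)c2)s1` gives 1280 nM. Within the data shown here, compound 3 differs from compound 2 by a 1.3-fold lower number from compound 2 to compound 3 (0.12 log units; within the scatter) and from compound 1 by a 1.7-fold higher number from compound 1 to compound 3 (0.23 log units; within the scatter), so all three sit close together; the only step beyond the scatter is a 2.2-fold higher number from compound 1 to compound 2 (0.35 log units; beyond the scatter).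

Compound 4 `O=C(O)CCc1nnc(C(=O)Nc2cccc(-c3ccco3)c2)s1` makes a larger change: furan-2-yl in place of 4-fluorophenyl on an aromatic carbon. Among the measured compounds shown here, none of the measured steps swaps the whole ring, so they only show that changes on this part of the molecule have so far stayed small. Compound 4 is therefore expected to give 2000 nM, with a range from 700 nM to 6000 nM. The expected step is a 1.6-fold higher number from compound 3 to compound 4 (0.19 log units; within the scatter), which is estimated to stay modest.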

Compound 4, half-maximal effective concentration: 1640 nM
The estimate for compound 4 lay 1.2-fold (0.09 log units) above the measured number, and the stated range covers the measured number.
By their numbers in this assay, from the lowest: compounds 1, 3, 4 and 2 (each within the scatter of the next, the first and the last beyond it).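

Replacing the whole six-membered ring with furan-2-yl, which brings a ring oxygen and a hydrogen-bond acceptor, still leaves the number in this assay within the scatter, with a 1.3-fold higher number from compound 3 to compound 4 (0.11 log units; within the scatter) and a 1.0-fold lower number from compound 2 to compound 4 (0.01 log units; within the scatter) as the two steps. Among these compounds, the one step beyond the scatter is modest, at a 2.2-fold higher number from compound 1 to compound 4 (0.33 log units; beyond the scatter), so a smaller ring is accepted here about as well as the 4-fluorophenyl and 3-chlorophenyl rings, with compound 1 the exception. No supporting evidence is available to explain this. As far as these compounds go, whether a non-aromatic group at this place, such as an amine or a carboxylic acid, would shift the number further remains open.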